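Methyl on the benzyl ring of compound 2

This account rests on a few compounds, and the source may have more. Where it says the series, first, only, none or still open, it means among the compounds named here.

Compound 1 `CCN1C(=O)C(=O)c2cc(/C=C/C(=O)OC)ccc21` gives 200 nM in a functional assay on Jurkat cells (Homo sapiens) for antiproliferative activity, read by MTT assay, with a stated time of 48 h; a lower number here means a stronger inhibitor, a higher number a weaker inhibitor. Compound 2 `COC(=O)/C=C/c1ccc2c(c1)C(=O)C(=O)N2Cc1ccccc1` gives 70 nM. Going by the values given here, the one measured step, a 2.9-fold lower number from compound 1 to compound 2 (0.46 log units; beyond the scatter), is the only comparison available. Compound 2 holds the lowest of the two numbers; its nearest neighbour is compound 1, at the distance of that step.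

Compound 3 `COC(=O)/C=C/c1ccc2c(c1)C(=O)C(=O)N2Cc1ccc(C)cc1` differs from compound 2 by methyl in place of hydrogen on an aromatic carbon; cut one bond further out this reads phenyl to 4-methylphenyl, benzyl to 4-methylbenzyl. Among the compounds with values here, no measured step touches an aromatic carbon: the step of a 2.9-fold lower number from compound 1 to compound 2 (0.46 log units; beyond the scatter) exchanged a whole group on the chain carbon and does not bear directly on a methyl added to the ring. Nothing here points to a step beyond the scatter in either direction.

Compound 3 is therefore expected near compound 2, with the estimated step of a 1.1-fold lower number from compound 2 to compound 3 (0.03 log units; within the scatter) and an estimate of 65 nM, within 25 nM to 170 nM.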

Compound 3, half-maximal inhibitory concentration: 50 nM
For compound 3 the middle estimate is 1.3-fold (0.11 log units) above the measured one; low and high end bracket the measured number.
By their numbers in this assay, from the lowest: compounds 3 and 2 (each within the scatter of the next); then compound 1.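

In this assay the aromatic ring of the benzyl group accepts a methyl on an aromatic carbon, para to a large group, with a 1.4-fold lower number from compound 2 to compound 3 (0.15 log units; within the scatter), so compound 2 and compound 3 cannot be told apart at this position. With 4-methylphenyl in place of methyl on the chain carbon, the series shows a 4.0-fold lower number from compound 1 to compound 3 (0.60 log units; beyond the scatter), so the separation from the ethyl-bearing compound persists with the ring methyl present. No available measurement accounts for these numbers.

A single methyl leaves open how far this ring carbon accepts other groups, such as chlorine, methoxy or a carboxylic acid. The compounds shown also leave open whether the same methyl behaves alike on other carbons of the ring, and whether a longer chain between the ring and the nitrogen preserves these numbers.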